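Swapping a fluorophenyl for a pyridyl on the pyrrolidine core

The source may hold more compounds than are shown below. What is called first, only, known or untested is meant among the compounds shown, and "the series" means these compounds.

Compound 1: `COc1ccccc1C1CCCN1C(=O)C(Nc1ccccc1)c1ccc(C(F)(F)F)cc1` gives 33 nM
Compound 2: `O=C(C(Nc1ccccc1F)c1ccc(C(F)(F)F)cc1)N1CCCC1c1ccc(F)cc1` gives 37 nM

Both compounds were tested in an assay on HEK293 cells for antagonist activity at transient receptor potential M8 protein (Canis lupus familiaris), read by fluorescence and calcium flux, with a stated time of 5 min; a lower number here means a stronger inhibitor, a higher number a weaker inhibitor. Of the two numbers, compound 2 has the higher one, but compound 1 sits so close to it that the gap is within the scatter of repeated measurement, so the two count as equally strong inhibitors on this evidence.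

Compound 3, `O=C(C(Nc1ccccc1F)c1ccc(C(F)(F)F)cc1)N1CCCC1c1cccnc1`, is the next variant. It differs from compound 2 in one place: pyridin-3-yl in place of 4-fluorophenyl on a saturated ring carbon. The change sits on the saturated ring carbon that carries the aryl group, and nothing else in the molecule moves.

Within the data shown here, no step between measured compounds shows what such a replacement does, so the expectation rests only on the general experience that swapping one six-membered aromatic ring for a closely related one usually shifts potency by a modest amount rather than abolishing it. For compound 3 the step expected from this replacement is a 2.7-fold higher number from compound 2 to compound 3 (0.43 log units; beyond the scatter), a weakening that could well fall inside the scatter. Compound 3 is therefore estimated at 100 nM, with a plausible range from 30 nM to 350 nM.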

Compound 3, half-maximal inhibitory concentration: 7 nM
The estimate for compound 3 lay 14-fold (1.15 log units) above the measured number; measured number outside the range, below it.
By their numbers in this assay, from the lowest: compound 3; then compounds 1 and 2 (each within the scatter of the next).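

In this assay, pyridin-3-yl in place of 4-fluorophenyl on the saturated ring carbon gives a 5.3-fold lower number from compound 2 to compound 3 (0.72 log units; beyond the scatter), a gain in potency that lies beyond the scatter. Compounds 1 and 2 differ in more than one place, so they could not show what the aryl group on this carbon does by itself; this single change shows that the choice of ring here matters, and that a 4-fluorophenyl is not needed for potency in this series, at least with the rest of compound 2 held fixed. Nothing measured here explains why the number falls with this replacement.

The change removes a fluorine and brings in a ring nitrogen with one hydrogen-bond acceptor at the same time, so the compounds shown cannot say which of these matters, and a plain phenyl on the same carbon would help to separate the two. Going by these compounds, whether the placing of the ring nitrogen counts also remains open, a question that pyridin-2-yl or pyridin-4-yl on this carbon would address.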